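Swapping the Ester Ketone Arm for a Biphenyl

The compounds below may be only part of what the source reports. "The series", "measured", "known", "first", "only" and "open" are said of these compounds alone.

Measured compounds:
- compound 1, `CCCc1nc(CC)c(C(=O)OCC(=O)c2ccccc2)n1Cc1ccc(-c2ccccc2S(=O)(=O)NC(=O)OCCC(C)C)cc1F`: 2 nM
- compound 2, `CCCc1nc(CC)c(C(=O)OCc2ccccc2C(=O)c2ccccc2)n1Cc1ccc(-c2ccccc2S(=O)(=O)NC(=O)OCCc2ccccc2)cc1F`: 0.69 nM
- compound 3, `CCCc1nc(CC)c(C(=O)OC(C(=O)c2ccccc2)c2ccccc2)n1Cc1ccc(-c2ccccc2S(=O)(=O)NC(=O)OCCC(C)C)cc1F`: 3 nM

In an assay on isolated protein for binding affinity to Type-2 angiotensin II receptor (Homo sapiens) (on this read-out higher numbers stand for weaker inhibition and lower numbers for stronger inhibition), compound 1 gives 2 nM, the second highest of the numbers shown. Its nearest neighbour is compound 3, and the gap a 1.5-fold higher number from compound 1 to compound 3 (0.18 log units; within the scatter) lies within the scatter. Compound 2 sits furthest away with a lower number, and that gap lies beyond the scatter, but compound 2 differs from compound 1 in more than one place, so its two values can only be noted side by side.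

Compound 4, `CCCc1nc(CC)c(C(=O)OCc2ccccc2-c2ccccc2)n1Cc1ccc(-c2ccccc2S(=O)(=O)NC(=O)OCCC(C)C)cc1F`, has not been measured. Against compound 1 the difference is 2-phenylphenyl in place of benzoyl on a saturated chain carbon bound to an oxygen next to a carbonyl group. Within the data shown here, the only measured step that touches this region is the one from compound 1 to compound 3, where a phenyl was added at a nearby chain carbon and the number barely moved. Replacing benzoyl by 2-phenylphenyl is a larger change, yet nothing measured points to a shift in a particular direction. Compound 4 is therefore expected to stay close to compound 1, with the estimated step of a 1.3-fold higher number from compound 1 to compound 4 (0.10 log units; within the scatter). The estimate for compound 4 is 2.5 nM, with a range from 0.9 nM to 7 nM.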

Compound 4, half-maximal inhibitory concentration: 9 nM
Compound 4: the middle estimate sits 3.6-fold (0.56 log units) below what was measured; the measured number lies above the stated range.
By their numbers in this assay, from the lowest: compound 2; then compounds 1 and 3 (each within the scatter of the next); then compound 4.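

At the saturated chain carbon bound to an oxygen next to a carbonyl group, the arm cannot be exchanged freely in this assay: 2-phenylphenyl in place of benzoyl gives a real change (a 4.5-fold higher number from compound 1 to compound 4 (0.65 log units; beyond the scatter)), whereas adding phenyl gave only a small one (a 1.5-fold higher number from compound 1 to compound 3 (0.18 log units; within the scatter)). The exchange alters several things at once, as benzoyl carries a carbonyl and a hydrogen-bond acceptor, while 2-phenylphenyl carries neither and has more heavy atoms. Nothing available explains which of these differences accounts for the step.

The compounds shown leave open whether the loss of the carbonyl or the larger arm sets the number. They also leave open how a cyclohexyl group, an amine or a carboxylic acid would behave on the same chain carbon.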